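A Butyl Chain in Place of Hydroxymethyl

This account rests on a few compounds, and the source may have more. Where it says the series, first, only, none or still open, it means among the compounds named here.

In a functional assay on MDA-MB-231 cells (Homo sapiens) for antiproliferative activity, read by sulforhodamine B assay, with a stated time of 48 h (a lower number here means a stronger inhibitor of growth, a higher number a weaker inhibitor of growth), compound 1 `O=C1COc2ccccc2N1CCCn1cc(-c2ccccc2)nn1` gives 4900 nM, compound 2 `O=C1COc2ccccc2N1CCCn1cc(-c2cccnc2)nn1` gives 3000 nM, and compound 3 `O=C1COc2ccccc2N1CCCn1cc(CO)nn1` gives 5700 nM. Compound 3 cannot be separated from either of the others, since all three values lie within the scatter. Compound 4 `CCCCc1cn(CCCN2C(=O)COc3ccccc32)nn1` keeps the shared core and changes one group: propyl in place of hydroxy on a saturated chain carbon bound to an aromatic carbon. In effect, hydroxymethyl becomes butyl. The nearest evidence comes from earlier exchanges on the same aromatic carbon, a 1.2-fold higher number from compound 1 to compound 3 (0.07 log units; within the scatter) and a 1.9-fold higher number from compound 2 to compound 3 (0.28 log units; within the scatter), and neither exceeds the scatter. No step beyond the scatter is therefore expected in this assay. The expected step is a 1.3-fold lower number from compound 3 to compound 4 (0.10 log units; within the scatter). For compound 4 the estimated value is 4500 nM, with an expected range of 2000 nM to 10000 nM.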

Compound 4, concentration for 50% growth inhibition: 3600 nM
Estimate against measurement, compound 4: 1.3-fold (0.10 log units) above; the measured number falls inside the stated range.
By their numbers in this assay, from the lowest: compounds 2, 4, 1 and 3 (each within the scatter of the next).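

Butyl in place of hydroxymethyl gives a 1.6-fold lower number from compound 3 to compound 4 (0.20 log units; within the scatter) in this assay and so the hydroxy, with its hydrogen-bond donor and acceptor, can leave this chain without a step beyond the scatter. A chain with no ring also matches the aromatic groups on the same aromatic carbon, with a 1.2-fold higher number from compound 2 to compound 4 (0.08 log units; within the scatter) against pyridin-3-yl and a 1.4-fold lower number from compound 1 to compound 4 (0.13 log units; within the scatter) against phenyl. No measured evidence here explains why these exchanges stay so small. As far as these compounds go, whether an amine, a carboxylic acid or a chain longer than butyl on this carbon would give a step beyond the scatter remains open.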